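This account rests on a few compounds, and the source may have more. Where it says the series, first, only, none or still open, it means among the compounds named here.

Of the compounds shown here, two built on one shared core have been measured in an assay on isolated protein for inhibition of Apoptosis regulator Bcl-2 (Homo sapiens), read by fluorescence polarization, with stated times of 5 min and 10 min; on this read-out lower numbers stand for stronger inhibition and higher numbers for weaker inhibition. Compound 1 `CC(C)=CCCC1=CC[C@H](C(=O)N(C)O)[C@@H](c2ccccc2)C1` carries a hydroxy on its amide-type nitrogen, and in this assay compound 1 gives 2100 nM. Compound 2 `CC(C)=CCCC1=CC[C@H](C(=O)N(C)C)[C@@H](c2ccccc2)C1` carries a methyl in that place instead. In this assay compound 2 gives > 23000 nM, which is a limit of the assay rather than a number. The step of an at least 10-fold higher number from compound 1 to compound 2 (1.03 log units; beyond the scatter) is thus a large loss, and compound 2 sits at the limit of > 23000 nM in this assay, at which 1 of the 2 values shown sits.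

Compound 3 `CON(C)C(=O)[C@H]1CC=C(CCC=C(C)C)C[C@@H]1c1ccccc1` is one further move from compound 2: methoxy in place of methyl on an amide-type nitrogen. Within the data shown here, only the step from compound 1 to compound 2 bears on this change, and it showed that swapping hydroxy for methyl on this nitrogen costs a great deal. A methoxy is neither a hydroxy nor a plain methyl, so a step in this assay of uncertain size is expected, most likely a modest gain at best. The estimate for compound 3 is 20000 nM, with a range from 5000 nM to 60000 nM, meaning an expected step of an at least 1.1-fold lower number from compound 2 to compound 3 (0.06 log units; that floor lies within the scatter).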

Compound 3, inhibition constant: 300 nM
The estimate for compound 3 lay 67-fold (1.82 log units) above the measured number; measured number outside the range, below it.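

In this assay, replacing the methyl on the amide-type nitrogen with methoxy gives an at least 76-fold lower number from compound 2 to compound 3 (1.88 log units; beyond the scatter), so a group on this nitrogen that holds an oxygen can restore binding and surpass the hydroxy of compound 1. Placing a methyl on the oxygen of that hydroxy does no harm, giving a 7.0-fold lower number from compound 1 to compound 3 (0.85 log units; beyond the scatter), which shows that the hydrogen of the hydroxy is not needed for a low number in these compounds, and the earlier loss on going to compound 2 cannot be read as a need for a free hydroxy. Compound 2, the only one of the three without an oxygen on this nitrogen, stands at a limit of the assay and not at a number: the limit of > 23000 nM in this assay, at which 1 of the 3 values shown sits.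

The compounds shown leave open how far the improvement extends when the oxygen carries a longer chain, as in ethoxy or benzyloxy. They also leave open whether an oxygen is required at all, which an amino group on the same nitrogen in place of the methoxy would help to settle.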